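Aryl esters of the shared core: removing the nitro group

The compounds below may be only part of what the source reports. "The series", "measured", "known", "first", "only" and "open" are said of these compounds alone.

Measured compounds:
compound 1 `CC1=CC[C@H](C(C)C)c2cc(C)c(OC(=O)c3ccc(C)cc3)cc21` in a functional assay on HCT-15 cells (Homo sapiens) for antiproliferative activity, read by sulforhodamine B assay, with a stated time of 48 h, tested at 50 uM; on this read-out lower numbers stand for less inhibition and higher numbers for more inhibition at the one concentration tested (going by the name of the read-out): 78.9%
compound 2 `CC1=CC[C@H](C(C)C)c2cc(C)c(OC(=O)Nc3ccccc3)cc21` in this assay: 92%
compound 3 `CC1=CC[C@H](C(C)C)c2cc(C)c(OC(=O)c3ccc([N+](=O)[O-])cc3)cc21` in this assay: 67.8%

Compound 3 gives the lowest of the three numbers in this assay. The nearest is compound 1, the step being a number 11.1 percentage points lower from compound 1 to compound 3 (beyond the scatter); the furthest is compound 2, with a number 24.2 percentage points lower from compound 2 to compound 3 (beyond the scatter). The shared core is kept throughout; only the group on the carbonyl carbon changes.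

Compound 4 `CC1=CC[C@H](C(C)C)c2cc(C)c(OC(=O)c3ccccc3)cc21` is the next member. It differs from compound 3 in one place: hydrogen in place of nitro on an aromatic carbon. Of the measured steps, the one that bears on this change is the introduction of the nitro group, a number 11.1 percentage points lower from compound 1 to compound 3 (beyond the scatter), which went with a modest loss. The step from compound 2 to compound 3, a number 24.2 percentage points lower from compound 2 to compound 3 (beyond the scatter), changes both the aryl group and the linking atom and is less direct. Within the data shown here, only one step speaks to the nitro group, so the expectation rests on a single comparison.

Removing the nitro group is expected to reverse part or all of that loss, giving a modest rise in this assay for compound 4, with the step of a number 10.2 percentage points higher from compound 3 to compound 4 (beyond the scatter). Compound 4 is therefore estimated at 78%, within 65% to 90%.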

Compound 4, a percentage reported as inhibition, at one concentration (the size of the read-out at that concentration, not a potency): 49.5%
Compound 4: the middle estimate sits 28.5 percentage points above what was measured; the whole stated range lies above it.
By their numbers in this assay, from the lowest: compound 4; then compound 3; then compound 1; then compound 2.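

In this assay, the loss seen on going from methyl to nitro does not mean that the bare ring is better: the step is a number 18.3 percentage points lower from compound 3 to compound 4 (beyond the scatter), so at this place, para to a large group, nitro goes with more inhibition than hydrogen. Methyl shows the same direction, with a number 29.4 percentage points lower from compound 1 to compound 4 (beyond the scatter), so among compound 1, compound 3 and compound 4 both substituents give higher numbers than hydrogen, and no compound in this small set goes against that, although the two substituents also differ from each other. The group on the carbonyl carbon matters more than any single ring substituent seen so far, since the change from anilino to phenyl gives a number 42.5 percentage points lower from compound 2 to compound 4 (beyond the scatter), the largest step in the series, and compound 4 holds the lowest number of the four.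

No measurement bears on why hydrogen falls below both methyl and nitro at this place. Open questions are whether a methoxy group, a chlorine atom or an amine at the same place would also lift the number above that of compound 4, and whether the same ring substituents would change the anilino compound 2 in the same direction.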